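The source may hold more compounds than are shown below. What is called first, only, known or untested is meant among the compounds shown, and "the series" means these compounds.

Compound 2 `Cc1cc(Nc2ccc(C(=O)/C=C/c3cccc(Br)n3)cc2)n2nc(SCc3ccc(Cl)cc3)nc2n1` gives 90.2% in a functional assay on MGC-803 cells (Homo sapiens) for inhibition, read by sulforhodamine B assay, with a stated time of 72 h, tested at 10 uM (a lower number here means less inhibition, a higher number more inhibition at the concentration tested (going by the name of the read-out)), level with compound 1 `Cc1cc(Nc2ccc(C(=O)/C=C/c3cccc(Br)n3)cc2)n2nc(SCc3ccccc3)nc2n1`, which gives 90.2%; together they are the highest of the three numbers, while compound 3 `Cc1nc2nc(SCc3ccc(Cl)cc3)nn2c(Nc2ccc(C(=O)/C=C/c3cccc(Br)n3)cc2)c1C` gives 72.5%. Compound 4 `Cc1cc(Nc2ccc(C(=O)/C=C/c3cccc(Br)n3)cc2)n2nc(SCc3ccc([N+](=O)[O-])cc3)nc2n1` differs from compound 2 by nitro in place of chloro on an aromatic carbon, the nitro group entering on an aromatic carbon of the six-membered aromatic ring of carbon only, para to a large group. The step that bears on this place is no change at the digits printed from compound 1 to compound 2 (within the scatter), where a group added at the same position left the number unchanged. The other step, a number 17.7 percentage points lower from compound 2 to compound 3 (beyond the scatter), lies on the shared core and does not speak to this change. Compound 4 is therefore expected to show no step beyond the scatter, a number 2.2 percentage points lower from compound 2 to compound 4 (within the scatter). Compound 4 is estimated at 88%, between 74% and 96%.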

Compound 4, a percentage reported as inhibition, at one concentration (the size of the read-out at that concentration, not a potency): 91.6%
Compound 4: middle estimate off by 3.6 percentage points, on the low side; the range from low to high includes it.
By their numbers in this assay, from the lowest: compound 3; then compounds 1, 2 and 4 (each within the scatter of the next).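

In this assay the change from 4-chlorophenyl to 4-nitrophenyl moves the number little (a number 1.4 percentage points higher from compound 2 to compound 4 (within the scatter)), and nitro in place of hydrogen does the same (a number 1.4 percentage points higher from compound 1 to compound 4 (within the scatter)). The position therefore takes not only chloro but also nitro, a larger group with hydrogen-bond acceptors, without a step beyond the scatter. No measurement shown accounts for this. As far as these compounds go, whether an amine or a carboxylic acid at this place would hold the number stays open, as does any effect of a longer chain there.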